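The source may report more compounds than this note shows. Statements on the series, on what has been measured and on what is new or still open speak of the compounds shown alone.

Measured in a functional assay on HeLa cells (Homo sapiens) for antiproliferative activity, read by sulforhodamine B assay; on this read-out higher numbers stand for weaker inhibition of growth and lower numbers for stronger inhibition of growth:
- compound 1 `CC[C@@H]1O[C@H](COCc2ccccc2)[C@@H](OCc2ccccc2)[C@H](OCc2ccccc2)[C@H]1OC(C)=O`: > 50000 nM, a limit
- compound 2 `CCCCCCCCCCCCCCCOC[C@H]1O[C@@H](CCC)[C@H](O)[C@@H](OCCCCCCCCCCCCCCC)[C@@H]1OCCCCCCCCCCCCCCC`: > 50000 nM, a limit

Among the compounds with values here, the series so far offers only (the limit of > 50000 nM in this assay, at which 2 of the 2 values shown sit). In this assay, compound 2 stands at > 50000 nM, which is a limit and not a number. Compound 3 `CCCCCCCCCCCCCCCOC[C@H]1O[C@H](CCC)[C@H](O)[C@@H](OCCCCCCCCCCCCCCC)[C@@H]1OCCCCCCCCCCCCCCC` has the same atoms and bonds as compound 2: the two compounds have the same atoms and bonds and differ only in configuration as drawn: 1 of 5 stereo elements differ; a stereocentre at a saturated ring carbon is drawn S in compound 2 and R in compound 3. Within the data shown here, no measured step gives a size for such a change. The expected a number no higher from compound 2 to compound 3 (the limit leaves the size open) is none beyond the scatter, in no particular direction, and a further limit is the likeliest report. For compound 3 the estimate is 50000 nM, with an expected range of 12000 nM to 100000 nM.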

Compound 3, concentration for 50% growth inhibition: 28700 nM
For compound 3 the middle estimate is 1.7-fold (0.24 log units) above the measured one, and the stated range covers the measured number.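

In this assay, the change at this saturated ring carbon from S to R gives an at least 1.7-fold lower number from compound 2 to compound 3 (0.24 log units; that floor lies within the scatter). Within the data shown here, compound 3, at 28700 nM, provides the first actual number, so configuration at this carbon is the first change with a measured value on one side. The change is one of configuration alone: the fact that compounds 2 and 3 differ only in the configuration as drawn

On these data alone, it remains open whether the true step lies beyond the scatter. As far as these compounds go, it is also open whether the R configuration still gives a number when an amine or shorter chains replace the long ether chains.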